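The source may report more compounds than this note shows. Statements on the series, on what has been measured and on what is new or still open speak of the compounds shown alone.

In an ADME assay on GES1 cells (Homo sapiens) for inhibition, read by MTT assay, with a stated time of 72 h (a lower number here means a stronger inhibitor, a higher number a weaker inhibitor), three compounds that differ only in the group on the sulfur have been measured. Compound 1 `Cc1cc(Nc2cc(-c3ccccc3)[nH]n2)n2nc(SCc3cccc(Br)c3)nc2n1` reads > 50000 nM, which is a limit of the assay and not a number. Among the compounds with values here, compound 2 `Cc1cc(Nc2cc(-c3ccccc3)[nH]n2)n2nc(SCc3ccc(Cl)cc3)nc2n1` gives 31800 nM, and compound 3 `C#CCSc1nc2nc(C)cc(Nc3cc(-c4ccccc4)[nH]n3)n2n1` gives 45700 nM, so compound 3 stands within the scatter of its only measured neighbour.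

The next compound, compound 4 `Cc1cc(Nc2cc(-c3ccccc3)[nH]n2)n2nc(SCc3ccc(C(F)(F)F)cc3)nc2n1`, changes that same group: 4-(trifluoromethyl)phenyl in place of ethynyl on a saturated chain carbon bound to a sulfur. In words, 4-(trifluoromethyl)phenyl takes the place of ethynyl on a saturated chain carbon bound to a sulfur.

The closest evidence is the reverse kind of swap, a ring-bearing group giving way to ethynyl, which produced a 1.4-fold higher number from compound 2 to compound 3 (0.16 log units; within the scatter). The two steps that start from the limit, an at least 1.5-fold lower number from compound 1 to compound 2 (0.19 log units; that floor lies within the scatter) and an at least 1.0-fold lower number from compound 1 to compound 3 (0.03 log units; that floor lies within the scatter), are only floors. Together they show no change at this place that clearly exceeds the scatter, so no step beyond the scatter is expected in this assay. The best guide is compound 2 at 31800 nM, whose 4-chlorophenyl group is the nearest match to the incoming group.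

The expected step is a 1.4-fold lower number from compound 3 to compound 4 (0.14 log units; within the scatter). For compound 4 the estimated value is 33000 nM, with an expected range of 14000 nM to 55000 nM.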

Compound 4, half-maximal inhibitory concentration: 42700 nM
Beside the measured number, compound 4's estimate is 1.3-fold (0.11 log units) below it; low and high end bracket the measured number.
By their numbers in this assay, from the lowest: compounds 2, 4 and 3 (each within the scatter of the next). At a limit, above all of these: compound 1.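

In this assay, putting 4-(trifluoromethyl)phenyl in place of ethynyl on a saturated chain carbon bound to a sulfur gives a 1.1-fold lower number from compound 3 to compound 4 (0.03 log units; within the scatter), so this second pairing of a ring-bearing group with the ringless propargyl group again separates nothing, and compounds 2, 3 and 4 cannot be told apart at this position. The comparison of compound 2 and compound 4 adds a swap on the aromatic ring itself, trifluoromethyl in place of chloro on an aromatic carbon, and it gives a 1.3-fold higher number from compound 2 to compound 4 (0.13 log units; within the scatter), so this swap is no more visible in the read-out than the exchange of the whole group. Compound 1 reads as a limit of the assay and not as a number, so an at least 1.1-fold lower number from compound 1 to compound 4 (0.06 log units; that floor lies within the scatter) is only a floor: the limit of > 50000 nM in this assay, at which 1 of the 4 values shown sits.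

As far as these compounds go, it remains open whether any group on the sulfur can move the number in this assay clearly beyond the scatter, for instance a chain ending in an amine or a carboxylic acid, or a longer alkyl chain. Also open, from the compounds shown here alone, is how the number responds to changes made elsewhere on the shared core, since all four compounds carry the same core.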